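The compounds below may be only part of what the source reports. "The series", "measured", "known", "first", "only" and "open" are said of these compounds alone.

Working notes on the series. Compound 1 `COc1ccc(Nc2ncc3ccc(-c4ccccc4OC)n3n2)cc1` carries a methoxy on an aromatic carbon, and in an in vitro ADME assay on microsomes from liver (Homo sapiens) for metabolic stability, using NADPH, with a stated time of 10 min, tested at 0.5 uM (a lower number here means that the compound disappears faster, a higher number that the compound lasts longer), compound 1 gives 0.117 h. Among the compounds with values here, compound 2 `COc1ccccc1-c1ccc2cnc(Nc3ccc(S(=O)(=O)N(C)C)cc3)nn12` in this assay gives 0.0833 h; the step of a 1.4-fold lower number from compound 1 to compound 2 (0.15 log units; within the scatter) is the only measured one-change step in the set. Compound 3 `COc1ccccc1-c1ccc2cnc(Nc3cccc(N4CCN(C)CC4)c3)nn12` in this assay gives > 0.666 h, which is a limit of the assay and not a number. Within the data shown here, compound 3 thus stands at the limit of > 0.666 h in this assay, at which 1 of the 3 values shown sits; no step to compound 1 or compound 2 is computed, their values simply lie lower than that limit.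

Compound 4 `COc1ccccc1-c1ccc2cnc(Nc3cccc(N4CCN(C[C@H](C)O)CC4)c3)nn12` is not yet measured. Its change from compound 3 is 1-hydroxyethyl in place of hydrogen on a saturated chain carbon bound to an amine nitrogen in a ring; the same difference cut one bond further out reads methyl to 2-hydroxypropyl, 4-methylpiperazin-1-yl to 4-(2-hydroxypropyl)piperazin-1-yl. Among the measured compounds shown here, no measured step touches this part of the molecule; the only measured step, a 1.4-fold lower number from compound 1 to compound 2 (0.15 log units; within the scatter), concerns the aromatic substituent and lay within the scatter. On that basis no step beyond the scatter is expected from compound 3 to compound 4 in this assay, a step that the limit leaves unreadable from compound 3 to compound 4, though starting from a limit leaves the direction uncertain. Compound 4 is expected to give about 1 h in this assay, within a range from 0.4 h to 2.5 h, most likely again reported as a limit.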

Compound 4, half-life: 0.533 h
Compound 4: middle estimate off by 1.9-fold (0.27 log units), on the high side; the range from low to high includes it.
By their numbers in this assay, from the lowest: compounds 2 and 1 (each within the scatter of the next); then compound 4. At a limit, above all of these: compound 3.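

Within the data shown here, compounds 3 and 4 give the only measured change at this position, on a saturated chain carbon bound to an amine nitrogen in a ring, and with 4-(2-hydroxypropyl)piperazin-1-yl in place of 4-methylpiperazin-1-yl, compound 4 gives a number in this assay (0.533 h) rather than a limit. Read as a step, the change is an at least 1.2-fold lower number from compound 3 to compound 4 (0.09 log units; that floor lies within the scatter) and only that floor is known, so it neither shows nor excludes a change beyond the scatter. The reading for compound 3 is a limit of the assay and not a number, so the full size of the step cannot be read: the limit of > 0.666 h in this assay, at which 1 of the 4 values shown sits.

The compounds shown leave open whether any drop in half-life goes with the longer chain itself or with its hydroxy group, a question that a plain propyl or a 2-methoxypropyl group at this position would address. They also leave open how the opposite stereoisomer of the 2-hydroxypropyl group, or a chain ending in a carboxylic acid, would read in this assay on the same core.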